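Swapping the Halogenated Ring on the Amide Nitrogen

The compounds below may be only part of what the source reports. "The series", "measured", "known", "first", "only" and "open" are said of these compounds alone.

Among the measured compounds shown here, compound 2 `O=C(CN1CCN(c2nnc(Cc3ccncc3)c3ccccc23)CC1)Nc1ccc(F)c(F)c1` stands at the lowest of the two numbers measured so far in a functional assay on MDA-MB-231 cells (Homo sapiens) for cytotoxicity, read by MTT assay, with a stated time of 72 h (a lower number here means a stronger inhibitor, a higher number a weaker inhibitor), with 0.84 nM. For the measured compounds named here, its only neighbour, compound 1 `Cc1cccc(Cl)c1NC(=O)CN1CCN(c2nnc(Cc3ccncc3)c3ccccc23)CC1`, gives 2670 nM in this assay. Compound 3 `O=C(CN1CCN(c2nnc(Cc3ccncc3)c3ccccc23)CC1)Nc1ccc(Br)cc1` differs from compound 2 by 4-bromophenyl in place of 3,4-difluorophenyl on an amide-type nitrogen. Going by the values given here, the single step that bears on this change, a 3200-fold lower number from compound 1 to compound 2 (3.50 log units; beyond the scatter), shows that the ring on the amide-type nitrogen can shift the number a long way. That step compared a different pair of rings, so it fixes no direction here and leaves the range wide. Compound 3 is therefore expected near 3 nM, between 0.5 nM and 30 nM, an estimated step of a 3.6-fold higher number from compound 2 to compound 3 (0.55 log units; beyond the scatter).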

Compound 3, half-maximal inhibitory concentration: 19 nM
The estimate for compound 3 lay 6.3-fold (0.80 log units) below the measured number; the range from low to high includes it.
By their numbers in this assay, from the lowest: compound 2; then compound 3; then compound 1.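

In this assay, a step of a 23-fold higher number from compound 2 to compound 3 (1.35 log units; beyond the scatter) shows that two halogen-bearing phenyl rings on the amide-type nitrogen are not interchangeable. With a 140-fold lower number from compound 1 to compound 3 (2.15 log units; beyond the scatter) as well, the 4-bromophenyl ring also stands far from 2-chloro-6-methylphenyl, so low numbers are not tied to the 3,4-difluorophenyl ring alone.

Still open, on these data alone, is whether the bromine, the two fluorines or their placing on the ring sets the gap, and where a phenyl ring carrying an amine or a carboxylic acid would fall. No measurement given here explains the order of these three rings.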